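A few compounds are considered here, and "the series" means these few. Any claim that something is new, unique, unknown or untested is made for them only; others in the source may bear on it.

Values in a functional assay on HCT-15 cells (Homo sapiens); a higher number here means that more compound is needed for the effect, a lower number that less compound is needed:
- compound 1 `COc1cc(C2OC(c3ccc(N(C)C)cc3)=NN2C(C)=O)cc(OC)c1OC`: 0.033 uM
- compound 2 `COc1cc(C2OC(c3cccc(N(C)C)c3)=NN2C(C)=O)cc(OC)c1OC`: 0.16 uM
- compound 3 `COc1cc(C2OC(c3ccc(N(C)C)cc3)=NN2C=O)cc(OC)c1OC`: 0.096 uM

Compound 3 stands within the scatter of compound 2, while the comparison with the remaining compound reads a 2.9-fold higher number from compound 1 to compound 3 (0.46 log units; beyond the scatter). Compound 4 `COC(=O)N1N=C(c2ccc(N(C)C)cc2)OC1c1cc(OC)c(OC)c(OC)c1` carries methoxy in place of hydrogen on a carbonyl carbon, formyl to methoxycarbonyl: methoxy in place of hydrogen on a carbonyl carbon.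

For the measured compounds named here, the only measured change on this carbonyl carbon is a 2.9-fold higher number from compound 1 to compound 3 (0.46 log units; beyond the scatter), with hydrogen in place of methyl. Read in reverse, it suggests a lower number when hydrogen is replaced, though methoxy is not methyl. The other measured change, a 4.8-fold higher number from compound 1 to compound 2 (0.69 log units; beyond the scatter), lies on the dimethylaminophenyl group and does not bear on this one. In this assay, a small drop, possibly within the scatter, is therefore expected: a 1.4-fold lower number from compound 3 to compound 4 (0.14 log units; within the scatter). The estimated value for compound 4 is 0.07 uM, with an expected range from 0.025 uM to 0.2 uM.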

Compound 4, concentration for half-maximal effect: 40 uM
For compound 4 the middle estimate is 570-fold (2.76 log units) below the measured one; the measured number lies above the stated range.
By their numbers in this assay, from the lowest: compound 1; then compounds 3 and 2 (each within the scatter of the next); then compound 4.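

In this assay, for the compounds shown here, the carbonyl carbon on the amide-type nitrogen in a ring proves far less forgiving than the earlier compounds suggested, with a 420-fold higher number from compound 3 to compound 4 (2.62 log units; beyond the scatter) and with a 1200-fold higher number from compound 1 to compound 4 (3.08 log units; beyond the scatter) for the two methoxy swaps. Hydrogen and methyl on this carbon differ only modestly, whereas methoxy breaks sharply from both. Nothing available explains this jump.

On these data alone, whether the step follows the oxygen of methoxy or simply the added heavy atoms stays open. Ethyl on the same carbonyl carbon, or an amine such as methylamino, would help separate the two readings.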